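The source may report more compounds than this note shows. Statements on the series, on what has been measured and on what is new or still open speak of the compounds shown alone.

Measured so far in an assay on isolated protein for inhibition of Amine oxidase [flavin-containing] A (Homo sapiens), read by fluorescence, with a stated time of 30 min; a lower number here means a stronger inhibitor, a higher number a weaker inhibitor:
- compound 1 `CCN(CCCCn1sc2cc(OC)c(OC)cc2c1=O)Cc1ccccc1OC` gives 9600 nM
- compound 2 `COc1ccccc1CN(C)CCCCCCn1sc2cc(OC)c(OC)cc2c1=O` gives 19900 nM
- compound 3 `CCN(CCCCCCn1sc2cc(OC)c(OC)cc2c1=O)Cc1ccccc1OC` gives 7900 nM

Compound 3 shows the lowest number of the three, yet compound 1 sits within the usual scatter of it, so the two cannot be ranked against each other. Only compound 2 stands clearly apart: the step of a 2.5-fold lower number from compound 2 to compound 3 (0.40 log units; beyond the scatter) is a modest one, beyond the scatter, and it concerns the group on the amine nitrogen.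

Compound 4 `CCN(CCCCCCn1sc2cc(OC)c(OC)cc2c1=O)Cc1ccc(N(C)C)cc1` is reached from compound 3 by a different change: 4-(dimethylamino)phenyl in place of 2-methoxyphenyl on a saturated chain carbon bound to an amine nitrogen. Among the measured compounds shown here, none of the measured steps touches this part of the molecule; the one step that exists, from the methyl of compound 2 to the ethyl of compound 3, sits elsewhere and gives no guide to swapping one aromatic group for another. The expectation therefore rests on the shared core and chain being unchanged, and is that compound 4 remains in the same broad range as compound 3, with a step of a 1.3-fold higher number from compound 3 to compound 4 (0.10 log units; within the scatter) that is expected to be small and could fall either way. The estimate for compound 4 in this assay is 10000 nM, expected between 3000 nM and 35000 nM.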

Compound 4, half-maximal inhibitory concentration: 7100 nM
Beside the measured number, compound 4's estimate is 1.4-fold (0.15 log units) above it; the measured number falls inside the stated range.
By their numbers in this assay, from the lowest: compounds 4, 3 and 1 (each within the scatter of the next); then compound 2.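

Until now the measured steps touched only the small group on the amine nitrogen, so the aromatic group on a saturated chain carbon bound to an amine nitrogen had not been tested. In this assay, putting 4-(dimethylamino)phenyl in place of 2-methoxyphenyl gives a 1.1-fold lower number from compound 3 to compound 4 (0.05 log units; within the scatter), so the two groups cannot be told apart here, even though they differ in both their substituent and its place on the ring. No measurement at hand explains why the two numbers read alike.

The compounds shown leave open whether any aromatic group would read the same at this position, since a plain phenyl, a 4-methoxyphenyl or a pyridine ring does not appear among them. They also leave open whether the same swap would read alike on the shorter chain of compound 1.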